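The source may hold more compounds than are shown below. What is called first, only, known or untested is meant among the compounds shown, and "the series" means these compounds.

Working notes on the urea series.

The shared core of compound 1 `O=C(Nc1cccc(OCc2cn(-c3ccccc3)nn2)c1)Nc1ccc(Cl)c(C(F)(F)F)c1` gives 1780 nM in a functional assay on HepG2 cells (Homo sapiens) for inhibition, read by MTT assay, with a stated time of 72 h; on this read-out higher numbers stand for weaker inhibition and lower numbers for stronger inhibition. Compound 2 `COc1ccc(-n2cc(COc3cccc(NC(=O)Nc4ccc(Cl)c(C(F)(F)F)c4)c3)nn2)cc1` gives 4680 nM in this assay, and the step of a 2.6-fold higher number from compound 1 to compound 2 (0.42 log units; beyond the scatter) shows that a methoxy at this position weakens inhibition beyond the scatter. Compound 3 `N#Cc1ccccc1-n1cc(COc2cccc(NC(=O)Nc3ccc(Cl)c(C(F)(F)F)c3)c2)nn1` gives 1970 nM, and a 1.1-fold higher number from compound 1 to compound 3 (0.04 log units; within the scatter) stays within the scatter, so compound 1 and compound 3 cannot be ordered. Compound 3 stands second highest of the three numbers, with compound 1 nearest and compound 2 furthest, as a 2.4-fold lower number from compound 2 to compound 3 (0.38 log units; beyond the scatter) shows.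

Compound 4 `Cc1ccc(-n2cc(COc3cccc(NC(=O)Nc4ccc(Cl)c(C(F)(F)F)c4)c3)nn2)cc1` is the next member, carrying (4-methylphenyl in place of 2-cyanophenyl on an aromatic nitrogen). The measured steps that bear on it are a 2.6-fold higher number from compound 1 to compound 2 (0.42 log units; beyond the scatter), where a 4-methoxyphenyl raised the number modestly, and a 2.4-fold lower number from compound 2 to compound 3 (0.38 log units; beyond the scatter), where the 2-cyanophenyl brought it back down. A 4-methylphenyl lacks the hydrogen-bond acceptor of both the methoxy and the nitrile, and the series gives no direct reading of a methyl on this ring. The expectation is that compound 4 falls between compound 1 and compound 2, a step of a 1.5-fold higher number from compound 3 to compound 4 (0.18 log units; within the scatter) that is expected to be small and possibly within the scatter. In this assay compound 4 is estimated at 3000 nM, with a range from 1500 nM to 6500 nM.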

Compound 4, half-maximal inhibitory concentration: 5430 nM
Beside the measured number, compound 4's estimate is 1.8-fold (0.26 log units) below it; low and high end bracket the measured number.
By their numbers in this assay, from the lowest: compounds 1 and 3 (each within the scatter of the next); then compounds 2 and 4 (each within the scatter of the next).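

In this assay, the 4-methylphenyl gives a 3.1-fold higher number from compound 1 to compound 4 (0.48 log units; beyond the scatter) and a 2.8-fold higher number from compound 3 to compound 4 (0.44 log units; beyond the scatter), so this change weakens inhibition modestly relative to both the unsubstituted phenyl and the 2-cyanophenyl. The step of a 1.2-fold higher number from compound 2 to compound 4 (0.06 log units; within the scatter) stays within the scatter, so methyl and methoxy cannot be ordered here, and the rise first seen with the 4-methoxyphenyl does not depend on the oxygen of the methoxy, since a simple methyl on the ring gives a number that cannot be told apart from it. No supporting measurement bears on why these two groups raise the number.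

The compounds shown leave open whether the ring position or the identity of the group decides the outcome, as the nitrile of compound 3 differs from the methyl and methoxy of compound 4 and compound 2 in both respects. They also give no reading of how an amine or a carboxylic acid on this ring would behave.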